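Removing a Side Chain from Compound 1

A few compounds are considered here, and "the series" means these few. Any claim that something is new, unique, unknown or untested is made for them only; others in the source may bear on it.

Compound 1 `C/C=C(\C)C1=C(CO)[C@H](O)[C@H]2O[C@H]2C1=O` is tested in a functional assay on SKW 6.4 cells (Homo sapiens) for cytotoxicity; on this read-out higher numbers stand for weaker inhibition and lower numbers for stronger inhibition. In this assay compound 1 gives only a limit of the assay, > 80000 nM (the limit of > 80000 nM in this assay, at which 1 of the 2 values shown sits). Compound 2 `O=C1C(/C=C/c2ccccc2)=C(CO)[C@H](O)[C@H]2O[C@@H]12` is a related compound; in this assay compound 2 gives 30000 nM. Compound 3 `O=C1C=C(CO)[C@H](O)[C@H]2O[C@@H]12` differs from compound 1 in one place: hydrogen in place of 1-methylprop-1-en-1-yl on a double-bonded ring carbon. For the measured compounds named here, no step between measured compounds is available to guide the size of this change; with compound 1 already at the limit, compound 3 is expected to stay weak, with a step of about a number no higher from compound 1 to compound 3 (the limit leaves the size open). Compound 3 is estimated at 80000 nM, between 30000 nM and 200000 nM, and most likely reported only as a limit.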

Compound 3, half-maximal inhibitory concentration: > 80000 nM
Compound 3: a limit, no number (the forecaster's own chance of this, stated with the estimate: 60%); the middle value sits exactly at the limit.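

In this assay, for the compounds shown here, compound 1 and compound 3 are both reported only as limits of the assay, and no step between them can be read. The compounds shown leave open whether replacing 1-methylprop-1-en-1-yl with hydrogen changes cytotoxicity at all.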